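A phenylsulfanyl group on the side chain of compound 1

This account rests on a few compounds, and the source may have more. Where it says the series, first, only, none or still open, it means among the compounds named here.

In a functional assay for inhibition, with Rattus norvegicus as the target (on this read-out lower numbers stand for an effect already at smaller amounts and higher numbers for an effect only at larger amounts of compound), compound 1 `CSCC[C@H](NC(=O)c1ccc(CN[C@H](C)CC2CCCCC2)cc1-c1ccccc1C)C(=O)O` gives > 1000 nM, which is a limit. Compound 2 `CSCC[C@H](NC(=O)c1ccc(CN(CCC2CCCCC2)Cc2ccccc2)cc1-c1ccccc1C)C(=O)O` gives > 1000 nM, also a limit. Compound 1 thus stands at the limit of > 1000 nM in this assay, at which 2 of the 3 values shown sit. Compound 3 `CSCC[C@H](NC(=O)c1ccc(CN(C)CCC2CCCCC2)cc1-c1ccccc1C)C(=O)O` gives 12 nM.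

Compound 4 `CSCC[C@H](NC(=O)c1ccc(CN[C@H](CSc2ccccc2)CC2CCCCC2)cc1-c1ccccc1C)C(=O)O` differs from compound 1 by phenylsulfanyl in place of hydrogen on a saturated chain carbon, two bonds along the chain from an amine nitrogen, phenylsulfanyl in place of hydrogen. Within the data shown here, no measured step makes this change. Among the measured compounds shown here, two steps bear on it indirectly, both large and both in the amine substituents: an at least 83-fold lower number from compound 1 to compound 3 (1.92 log units; beyond the scatter) and an at least 83-fold lower number from compound 2 to compound 3 (1.92 log units; beyond the scatter). The second removes a phenyl, so any gain remains uncertain. A large step to a lower number is still expected, namely an at least 16-fold lower number from compound 1 to compound 4 (1.22 log units; beyond the scatter). For compound 4 the estimated value is 60 nM, with an expected range of 4 nM to 1000 nM.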

Compound 4, half-maximal effective concentration: 12 nM
The estimate for compound 4 lay 5.0-fold (0.70 log units) above the measured number; measured number inside the range.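

Phenylsulfanyl in place of hydrogen on a saturated chain carbon, two bonds along the chain from an amine nitrogen, brings an at least 83-fold lower number from compound 1 to compound 4 (1.92 log units; beyond the scatter) in this assay. Among these compounds, the earlier steps touched only the amine substituents, and this is the first to show that a change at this carbon can move the read-out strongly. The full size of the step cannot be read, because the value of compound 1 is only a limit: the limit of > 1000 nM in this assay, at which 2 of the 4 values shown sit.

The compounds shown leave open whether a phenoxy or benzyl group on this carbon would act like phenylsulfanyl. They also leave open whether methylsulfanyl, without the ring, would suffice.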